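Exchanging one halogenated pyridine for another

This account rests on a few compounds, and the source may have more. Where it says the series, first, only, none or still open, it means among the compounds named here.

In an ADME assay on A549 cells (Homo sapiens) for cytotoxicity, read by resazurin assay, with a stated time of 48 h (a lower number here means that less compound is tolerated, a higher number that more compound is tolerated), compound 1 (`O=C(Nc1ccc(NCc2ccccc2)cc1Cl)c1cc(Cl)ccc1O`) gives 19700 nM and compound 2 (`O=C(Nc1ccc(NCc2cnccc2Cl)cc1Cl)c1cc(Cl)ccc1O`) gives 126000 nM, the higher of the two numbers. For the measured compounds named here, the only measured step, a 6.4-fold higher number from compound 1 to compound 2 (0.81 log units; beyond the scatter), lies beyond the scatter and comes with 4-chloropyridin-3-yl in place of phenyl on a saturated chain carbon bound to a nitrogen on an aromatic ring. Compound 3 (`O=C(Nc1ccc(NCc2cccc(Br)n2)cc1Cl)c1cc(Cl)ccc1O`) has 6-bromopyridin-2-yl in place of 4-chloropyridin-3-yl at that same place: 6-bromopyridin-2-yl in place of 4-chloropyridin-3-yl on a saturated chain carbon bound to a nitrogen on an aromatic ring. Going by the values given here, no measured step exchanges one halogenated pyridine for another, so the evidence is indirect. Among the compounds with values here, the size of a 6.4-fold higher number from compound 1 to compound 2 (0.81 log units; beyond the scatter) gives the only scale for a change at this place, and a partial return toward compound 1 at 19700 nM is expected. The expected change is a 2.1-fold lower number from compound 2 to compound 3 (0.32 log units; beyond the scatter), a lower number of modest size. For compound 3 the estimated value is 60000 nM, with an expected range of 20000 nM to 180000 nM.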

Compound 3, half-maximal cytotoxic concentration: 92300 nM
Beside the measured number, compound 3's estimate is 1.5-fold (0.19 log units) below it; the measured number falls inside the stated range.
By their numbers in this assay, from the lowest: compound 1; then compounds 3 and 2 (each within the scatter of the next).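

In this assay the exchange of 4-chloropyridin-3-yl for 6-bromopyridin-2-yl gives a 1.4-fold lower number from compound 2 to compound 3 (0.14 log units; within the scatter), so this position accepts a different halogen and a different pyridine attachment with no difference that can be read between the two compounds. Set against phenyl, the new group gives a 4.7-fold higher number from compound 1 to compound 3 (0.67 log units; beyond the scatter), so the separation from compound 1 is not confined to the one halogenated pyridine seen earlier and holds for both pyridines shown. No measurement on hand bears on the reason for this.

The compounds shown leave open whether the ring nitrogen or the halogen carries the separation from phenyl, and an unsubstituted pyridin-3-yl or a 4-chlorophenyl at this place would divide the two. Also open, going by these compounds, is how a ring bearing a carboxylic acid or an amine would read here.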